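From pyrazin-2-yl to pyrimidin-5-yl on a short-lived compound

A few compounds are considered here, and "the series" means these few. Any claim that something is new, unique, unknown or untested is made for them only; others in the source may bear on it.

Compound 1 `CSCC[C@H](NC(=O)c1ccc(CN(Cc2ccccc2)c2cnccn2)cc1-c1ccccc1C)C(=O)O` has no exact number in an ADME assay on the whole organism for metabolic stability, with Rattus norvegicus as the target; on this read-out higher numbers stand for a longer-lived compound and lower numbers for a shorter-lived compound. Compound 1 reports < 0.4 h, which is a limit and not a number. It therefore stands at the limit of < 0.4 h in this assay, at which 1 of the 2 values shown sits. Going by the values given here, the only other reading comes from compound 2 `CSCC[C@H](NC(=O)c1ccc(CN(Cc2cc(F)cc(F)c2)Cc2cncs2)cc1-c1ccccc1C)C(=O)O`, which differs from compound 1 in more than one place, and compound 2 gives 1.13 h.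

Compound 3 `CSCC[C@H](NC(=O)c1ccc(CN(Cc2ccccc2)c2cncnc2)cc1-c1ccccc1C)C(=O)O` keeps the core of compound 1 and changes one group, with pyrimidin-5-yl in place of pyrazin-2-yl on an amine nitrogen. The two compounds have the same atoms, joined differently. Among the compounds with values here, no measured pair isolates this change, and compound 2 cannot stand in for one. With so little to go on, no step beyond the scatter is expected in this assay, in either direction, and a second reading that gives only a limit would be no surprise. The expected step that the limit leaves unreadable from compound 1 to compound 3 stays within the scatter. For compound 3 the estimated half-life is 0.35 h, with an expected range of 0.15 h to 0.8 h.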

Compound 3, half-life: 0.5 h
Beside the measured number, compound 3's estimate is 1.4-fold (0.15 log units) below it; measured number inside the range.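

Placing pyrimidin-5-yl in place of pyrazin-2-yl on an amine nitrogen gives the first comparison in this assay that differs in one place, and it reads as an at least 1.2-fold higher number from compound 1 to compound 3 (0.09 log units; that floor lies within the scatter). Compound 3 also gives this position its first exact reading, 0.5 h. Compound 1 still stands only at a limit, < 0.4 h, so the change can be bounded on one side but not sized, and the printed floor does not establish a real difference between the two isomeric groups; the whole comparison rests on this point: the limit of < 0.4 h in this assay, at which 1 of the 3 values shown sits.

From the compounds shown here alone, the true gap between these two groups remains unknown, as does whether the change would read the same way on a compound carrying the 3,5-difluorobenzyl and thiazol-5-ylmethyl groups of compound 2, which differs from compound 1 and compound 3 in more than one place. Going by these compounds, it is also open how a pyridin-3-yl or pyridazin-4-yl group on the same amine nitrogen would read in this assay, and so whether the number or the placement of the ring nitrogen atoms matters at all here.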